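Replacing the 2,4-difluorophenyl group of compound 2

This account rests on a few compounds, and the source may have more. Where it says the series, first, only, none or still open, it means among the compounds named here.

Compound 1 `COc1ccc(-c2c[nH]c(=O)n2-c2cc(OC)c(OC)c(OC)c2)cc1N`: > 50000 nM
Compound 2 `COc1cc(-n2c(-c3ccc(F)cc3F)cn(C(C)=O)c2=O)cc(OC)c1OC`: 24100 nM

Within the data shown here, in a functional assay on A549 cells (Homo sapiens) for cytotoxicity, read by MTT assay, with a stated time of 48 h (a higher number here means a weaker inhibitor, a lower number a stronger inhibitor), compound 2 gives 24100 nM, the only actual number available so far. For compound 1 the reported > 50000 nM is a limit and not a number.

Compound 3 `COc1ccc(-c2cn(C(C)=O)c(=O)n2-c2cc(OC)c(OC)c(OC)c2)cc1N` has not yet been measured. It differs from compound 2 on an aromatic carbon, with 3-amino-4-methoxyphenyl in place of 2,4-difluorophenyl (3-amino-4-methoxyphenyl in place of 2,4-difluorophenyl on an aromatic carbon). Among the measured compounds shown here, no measured step covers this exchange, so any forecast for this assay is a judgement with wide uncertainty. A sizeable move toward stronger inhibition, beyond the usual scatter, is expected, and compound 2 at 24100 nM leaves ample room for such a move. The estimated change is an 8.0-fold lower number from compound 2 to compound 3 (0.90 log units; beyond the scatter). For compound 3 the expected half-maximal inhibitory concentration is 3000 nM, with an estimated range of 100 nM to 40000 nM.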

Compound 3, half-maximal inhibitory concentration: 1100 nM
Beside the measured number, compound 3's estimate is 2.7-fold (0.44 log units) above it; the range from low to high includes it.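

In this assay, the aromatic carbon of the five-membered ring proves sensitive to the aryl group it carries: 3-amino-4-methoxyphenyl in place of 2,4-difluorophenyl gives a 22-fold lower number from compound 2 to compound 3 (1.34 log units; beyond the scatter). With 3-amino-4-methoxyphenyl held in place, the aromatic nitrogen matters as well, since acetyl in place of hydrogen gives an at least 45-fold lower number from compound 1 to compound 3 (1.65 log units; beyond the scatter), so among these three compounds only compound 3, which carries both groups, reaches the low micromolar range. The second step has only a lower bound, as compound 1 is recorded as a limit and not as a number: the limit of > 50000 nM in this assay, at which 1 of the 3 values shown sits.

The compounds shown do not separate the amine from the methoxy group, as the two enter together, so a phenyl ring bearing only an amine or only a methoxy group, or an acetamide in place of the amine, could show which of them carries the step. They also leave open whether acetyl is specifically required on the ring nitrogen, or whether a longer acyl chain such as propanoyl, or a simple methyl group, would serve in its place.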